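Cyclopentyl for 2-fluorophenyl on the amine nitrogen

A few compounds are considered here, and "the series" means these few. Any claim that something is new, unique, unknown or untested is made for them only; others in the source may bear on it.

compound 1 `CCCc1ccc(NC2=CC(=O)c3nc4n(c3C2=O)[C@H]2OC[C@@H](O)[C@H]2OC4)cc1` gives > 4000 nM (a limit)
compound 2 `O=C1C(Nc2ccccc2F)=CC(=O)c2c1nc1n2[C@H]2OC[C@@H](O)[C@H]2OC1` gives 2660 nM

Among the measured compounds shown here, in a functional assay on ECa-109 cells for inhibition, with ECa-109 cell line (Homo sapiens) as the target, read by sulforhodamine B assay (a lower number here means a stronger inhibitor, a higher number a weaker inhibitor), compound 2 gives 2660 nM as the only true number so far. Compound 1 gives > 4000 nM as a limit of the assay and not a number. For the measured compounds named here, compound 2 is therefore the single numerical reference point, and no measured step between compounds differing in one place is available to scale from.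

The unmeasured compound 3 `O=C1C(NC2CCCC2)=CC(=O)c2c1nc1n2[C@H]2OC[C@@H](O)[C@H]2OC1` carries cyclopentyl in place of 2-fluorophenyl on an amine nitrogen on the otherwise shared core. Going by the values given here, no measured pair tests this change, so in this assay the working expectation is no step beyond the scatter and no firm direction. That expectation is anchored on compound 2 at 2660 nM and is held loosely. A report as a limit remains possible. The estimate amounts to a 1.1-fold higher number from compound 2 to compound 3 (0.05 log units; within the scatter) as an expected change. For compound 3 the expected value is 3000 nM with an estimated range from 1100 nM to 8000 nM in this read-out.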

Compound 3, half-maximal inhibitory concentration: > 16000 nM
Compound 3: no number, only a limit; the forecaster's own chance of this, stated with the estimate: 30%; at least 5.3-fold (0.72 log units) between middle value and limit.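

In this assay, the amine nitrogen now has its first readable step: cyclopentyl in place of 2-fluorophenyl gives an at least 6.0-fold higher number from compound 2 to compound 3 (0.77 log units; beyond the scatter). This shows that the group on this nitrogen is not interchangeable on the shared core, which compound 1 and compound 2 alone could not establish, and that this particular change goes towards the weaker end of the read-out. Compound 3 has only a limit and not a number: the limit of > 16000 nM in this assay, at which 1 of the 3 values shown sits.

The step therefore gives a minimum size, and the true size remains unknown; the single change also swaps the aromatic ring for a non-aromatic one and removes the fluorine together, so the two cannot be told apart here, and the data shown give no reason for the loss. Plain phenyl would separate the fluorine from the ring, while cyclohexyl or benzyl on the same nitrogen would show whether any other carbon ring can return to the level of compound 2 at 2660 nM.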